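The source may hold more compounds than are shown below. What is called first, only, known or untested is meant among the compounds shown, and "the series" means these compounds.

Compound 1 `Cc1cc(-c2ccccc2)n(/C(N)=N/S(=O)(=O)c2cc(C)c(Cl)cc2SCc2cccc(C(F)(F)F)c2)n1` gives 98000 nM in a functional assay on HeLa cells (Homo sapiens) for cytotoxicity, read by MTT assay, with a stated time of 72 h (a higher number here means a weaker inhibitor, a lower number a stronger inhibitor), the highest of the two numbers recorded here. Compound 2 `Cc1cc(S(=O)(=O)/N=C(\N)n2nccc2-c2ccccc2)c(SCc2ccccc2C)cc1Cl` gives 17000 nM in the same assay; the two differ in more than one place, so their values are noted only side by side. Compound 3 `Cc1cc(-c2ccccc2)n(/C(N)=N/S(=O)(=O)c2cc(C)c(Cl)cc2SCc2ccc(Cl)cc2)n1` carries the change 4-chlorophenyl in place of 3-(trifluoromethyl)phenyl on a saturated chain carbon bound to a sulfur and has not been measured. Among the measured compounds shown here, no step of that kind between measured compounds is available, so the expected move from compound 1 to compound 3 is a 1.6-fold lower number from compound 1 to compound 3 (0.21 log units; within the scatter), hardly beyond the scatter. Compound 3 is expected to give 60000 nM, within 20000 nM to 160000 nM.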

Compound 3, half-maximal inhibitory concentration: 3000 nM
For compound 3 the middle estimate is 20-fold (1.30 log units) above the measured one, outside the stated range (below it).
By their numbers in this assay, from the lowest: compound 3; then compound 2; then compound 1.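

In this assay, the group on the saturated chain carbon bound to a sulfur has a large bearing on the read-out: 4-chlorophenyl in place of 3-(trifluoromethyl)phenyl gives a 33-fold lower number from compound 1 to compound 3 (1.51 log units; beyond the scatter), a step well beyond the scatter. The data shown offer no measurement that accounts for this step. From the compounds shown here alone, what remains open is whether the step follows from the change of substituent or from its different place on the phenyl ring. Going by these compounds, how an unsubstituted phenyl or a phenyl carrying a carboxylic acid would behave here also remains unknown.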